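Series notes: compound 3 on the benzyl ring

A few compounds are considered here, and "the series" means these few. Any claim that something is new, unique, unknown or untested is made for them only; others in the source may bear on it.

Measured so far:
compound 1 `CNc1nc(NCc2ccc(OC(F)(F)F)cc2)cc(-c2ccccn2)n1` — 13 nM
compound 2 `CNC(=O)c1ccc(CNc2cc(-c3ccccn3)nc(NC)n2)cc1` — 30 nM

Among the compounds with values here, in a functional assay on HEK293 cells for agonist activity at G-protein coupled receptor 39 (Homo sapiens), read by inositol phosphate accumulation (a lower number here means that less compound is needed, a higher number that more compound is needed for the effect), compound 2 gives the highest of the two numbers so far; its nearest neighbour is compound 1, and the difference between them is a 2.3-fold higher number from compound 1 to compound 2 (0.36 log units; beyond the scatter). Compound 3 `CNc1nc(NCc2ccc(N(C)C(C)=O)cc2)cc(-c2ccccn2)n1` is the next unmeasured member. It differs from compound 2 by acetyl(methyl)amino in place of methylcarbamoyl on an aromatic carbon.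

Within the data shown here, no measured step touches this exact exchange; the only step known, from compound 1 to compound 2, swaps a different pair of groups at the same place and was modest in size, a 2.3-fold higher number from compound 1 to compound 2 (0.36 log units; beyond the scatter). Changes at this position have so far moved the read-out only modestly, so a step of similar size at most is expected here, most likely toward a somewhat higher number, with no firm direction. Compound 3 is therefore expected to give 45 nM in this assay, within 15 nM to 150 nM, an estimated step of a 1.5-fold higher number from compound 2 to compound 3 (0.18 log units; within the scatter).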

Compound 3, half-maximal effective concentration: 1180 nM
Beside the measured number, compound 3's estimate is 26-fold (1.42 log units) below it, and the stated range ends below it.
By their numbers in this assay, from the lowest: compound 1; then compound 2; then compound 3.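

In this assay, this position proves far less forgiving than the first two compounds suggested: the exchange of methylcarbamoyl for acetyl(methyl)amino gives a 39-fold higher number from compound 2 to compound 3 (1.59 log units; beyond the scatter), and the exchange of trifluoromethoxy for the same group gives a 91-fold higher number from compound 1 to compound 3 (1.96 log units; beyond the scatter), both well beyond the earlier 2.3-fold higher number from compound 1 to compound 2 (0.36 log units; beyond the scatter). Two closely matched amide-containing groups therefore do not read alike here, although methylcarbamoyl carries a hydrogen-bond donor and acetyl(methyl)amino carries none. Nothing available accounts for the size of this step.

The compounds shown leave open whether the higher number follows the methyl on the amide nitrogen or the reversed amide direction, which an acetylamino group would help separate. On these data alone, how an amine or a carboxylic acid would read on this aromatic carbon also remains open.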